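This account rests on a few compounds, and the source may have more. Where it says the series, first, only, none or still open, it means among the compounds named here.

The series is followed in an in vitro functional assay on SH-EP1 cells for agonist activity at Neuronal acetylcholine receptor; alpha4/beta2 (Homo sapiens), read by voltage clamp; on this read-out higher numbers stand for an effect only at larger amounts of compound and lower numbers for an effect already at smaller amounts. Compound 1 `C1=C(c2cncc(Oc3ccccc3)c2)CC2CNCC1C2` gives 590 nM in this assay. Among the compounds with values here, compound 2 `CC(C)Oc1cncc(C2=CC3CNCC(C2)C3)c1` gives 1400 nM in this assay, which is the higher of the two numbers measured so far; the only measured step, a 2.4-fold higher number from compound 1 to compound 2 (0.38 log units; beyond the scatter), separates it from compound 1. Compound 3 `CC(C)Oc1cncc(C2=CC3CC(C2)CN(C)C3)c1` has not yet been measured in this assay. It differs from compound 2 by methyl in place of hydrogen on an amine nitrogen in a ring. Within the data shown here, no measured step touches the amine nitrogen in the ring: the single step from compound 1 to compound 2 concerns the group on the oxygen on the aromatic ring and gives no guide to a methyl on that nitrogen. The expectation for compound 3 therefore rests on no direct comparison and must carry a wide range. The step expected in this assay is a 2.5-fold higher number from compound 2 to compound 3 (0.40 log units; beyond the scatter), with a result within the scatter not excluded. For compound 3 the estimate in this assay is 3500 nM, expected to fall between 900 nM and 14000 nM.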

Compound 3, half-maximal effective concentration: 3500 nM
For compound 3 middle estimate and measured number coincide at the digits printed, and the stated range covers the measured number.
By their numbers in this assay, from the lowest: compound 1; then compound 2; then compound 3.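

Methyl in place of hydrogen on an amine nitrogen in a ring gives a 2.5-fold higher number from compound 2 to compound 3 (0.40 log units; beyond the scatter) in this assay, the first reading at this position, and it shows that this nitrogen is not indifferent to substitution: a single added carbon moves the number beyond the scatter, to an extent that is modest. The change at the nitrogen is of much the same size as the earlier change on the oxygen on the aromatic ring, and in the same direction, so the shared core has now been altered at two separate places, with a higher number each time, while a number can still be read with the methyl in place. No measurement bears on what lies behind this step.

Open, as far as these compounds go, is whether a longer chain on the nitrogen, such as ethyl or propyl, or a benzyl group, would raise the number further or bring it back. Also open, from the compounds shown here alone, is whether methyl on the nitrogen gives a step of similar size when phenyl, as in compound 1, stands on the oxygen in place of isopropyl.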